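A few compounds are considered here, and "the series" means these few. Any claim that something is new, unique, unknown or untested is made for them only; others in the source may bear on it.

In a toxicity assay on THP-1 cells (Homo sapiens) for inhibition (a higher number here means that more compound is tolerated, a lower number that less compound is tolerated), the study has three measured compounds. Compound 1 `COc1ccc(-c2cnc(NC(=O)C3CCCC3)n2C)cc1` gives in this assay only the assay limit > 100000 nM, not a number. Compound 2 `COc1ccc(-c2cnc(NC(=O)c3ccc(F)cc3)n2C)cc1` gives in this assay likewise only a limit, >= 50000 nM. Compound 3 `COc1ccc(C(=O)Nc2ncc(-c3ccc(OC)cc3)n2C)cc1` stands in this assay at a limit as well, > 100000 nM. Since all three values are limits, compound 3 cannot be placed above or below the other two. The step that the two limits leave unreadable from compound 1 to compound 2, the step that the two limits leave unreadable from compound 1 to compound 3 and the step that the two limits leave unreadable from compound 2 to compound 3 all stay unreadable because the limit of > 100000 nM in this assay, at which 2 of the 3 values shown sit, and the limit of >= 50000 nM in this assay, at which 1 of the 3 values shown sits, cap the values. Compound 4 `COc1ccc(-c2cnc(NC(=O)c3ccc(O)cc3)n2C)cc1` differs from compound 3 by hydrogen in place of methyl on an oxygen on an aromatic ring. Among the compounds with values here, none of the measured steps changes anything on this oxygen, so no measured step bears directly on it, and each of them is unreadable anyway. Compound 4 is therefore expected in this assay to be tolerated at about 100000 nM, between 30000 nM and 300000 nM, most likely again reported as a limit. The expected step of a number no higher from compound 3 to compound 4 (the limit leaves the size open) is thus none beyond the scatter.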

Compound 4, half-maximal cytotoxic concentration: > 100000 nM
Compound 4 gave a limit, no number; the forecaster's own chance of this, stated with the estimate: 85%; the middle value lies on the limit itself.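

In this assay compound 4 gives > 100000 nM, a limit and not a number. Its steps from compound 1, compound 2 and compound 3 cannot be read. The compounds shown leave open at what concentration any of the four reaches its half-maximal cytotoxic effect in this assay, and whether any of these changes moves that concentration.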